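A Chlorine Shift Repeated on a Second Core

The source may hold more compounds than are shown below. What is called first, only, known or untested is meant among the compounds shown, and "the series" means these compounds.

Compound 1 `COc1ccccc1Oc1c(N)nc(-c2cccc(Cl)c2)nc1Cl` and compound 2 `COc1ccccc1Oc1c(N)nc(-c2ccc(Cl)cc2)nc1Cl` share one core and differ only in where the chlorine sits on the attached ring: 4-chlorophenyl in place of 3-chlorophenyl on an aromatic carbon. In a functional assay on A-375 cells (Homo sapiens) for cytotoxicity, read by CCK-8 assay, with a stated time of 24 h (on this read-out higher numbers stand for weaker inhibition and lower numbers for stronger inhibition), compound 1 gives 38300 nM, while compound 2 gives 1030 nM, a step of a 37-fold lower number from compound 1 to compound 2 (1.57 log units; beyond the scatter). Compound 3 `COc1ccccc1Oc1c(N)nc(-c2cccc(Cl)c2)nc1OCCO` is built on a second core, which differs from the core of compound 1 by 2-hydroxyethoxy in place of chloro on an aromatic carbon; in this assay compound 3 gives 30200 nM, and the step of a 1.3-fold lower number from compound 1 to compound 3 (0.10 log units; within the scatter) shows the two cores give much the same result. Compound 4 `COc1ccccc1Oc1c(N)nc(-c2ccc(Cl)cc2)nc1OCCO` carries the same kind of change onto the second core: 4-chlorophenyl in place of 3-chlorophenyl on an aromatic carbon. The surroundings are not identical, since the ring now sits meta to a 2-hydroxyethoxy group and para to a 2-methoxyphenoxy group rather than meta to a chloro group and para to a group of 9 heavy atoms, so this is the same kind of change, not the same change. Because the step of a 37-fold lower number from compound 1 to compound 2 (1.57 log units; beyond the scatter) was large, a similarly sized step is expected from compound 3 to compound 4, namely a 30-fold lower number from compound 3 to compound 4 (1.48 log units; beyond the scatter). For compound 4 in this assay the expected value is 1000 nM, most likely lying between 300 nM and 4000 nM.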

Compound 4, half-maximal inhibitory concentration: > 80000 nM
Compound 4 ended at the assay's limit (the forecaster's own chance of this, stated with the estimate: 2%); at least 80-fold (1.90 log units) between middle value and limit.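

In this assay compound 4 gives > 80000 nM, which is a limit of the assay and not a number. Even so, placing 4-chlorophenyl in place of 3-chlorophenyl on the second core gives an at least 2.6-fold higher number from compound 3 to compound 4 (0.42 log units; beyond the scatter), so the gain seen on the first core does not carry over, and the step runs the opposite way: the same change on two cores in this assay, a 37-fold lower number (1.57 log units; beyond the scatter) from compound 1 to compound 2 and an at least 2.6-fold higher number (0.42 log units; beyond the scatter) from compound 3 to compound 4, at least 98-fold (1.99 log units) apart, beyond the scatter of two such steps

This is a single pair of cores and gives no reason for the reversal, but the change of 2-hydroxyethoxy in place of chloro tells the same story, with a 1.3-fold lower number from compound 1 to compound 3 (0.10 log units; within the scatter) set against an at least 77-fold higher number from compound 2 to compound 4 (1.89 log units; beyond the scatter): the same change on two cores in this assay, a 1.3-fold lower number (0.10 log units; within the scatter) from compound 1 to compound 3 and an at least 77-fold higher number (1.89 log units; beyond the scatter) from compound 2 to compound 4, at least 98-fold (1.99 log units) apart, beyond the scatter of two such steps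

The compounds shown leave open whether the effect of moving the chlorine depends on the 2-hydroxyethoxy group in particular or would also change with another group at that place. An amine, or a longer chain ending in a carboxylic acid, in place of the 2-hydroxyethoxy group would be one way to test this, with both chlorophenyl groups compared on each new core.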